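Bis-sulfonamide series: a further analogue expected inactive

The compounds below may be only part of what the source reports. "The series", "measured", "known", "first", "only" and "open" are said of these compounds alone.

Compound 1 `COc1ccc(S(=O)(=O)Nc2ccc(NS(=O)(=O)c3ccc(F)cc3)cc2)cc1` is one of three bis-sulfonamides measured in an assay for inhibition of liver carboxylesterase 1 (Homo sapiens), read by spectrophotometry; on this read-out lower numbers stand for stronger inhibition and higher numbers for weaker inhibition. In this assay compound 1 gives only a limit, > 100000 nM. Compound 2 `Cc1ccc(S(=O)(=O)Nc2ccc(NS(=O)(=O)c3ccc(F)cc3F)cc2)cc1` likewise returns a limit in this assay, > 100000 nM. Compound 3 `CNC(=O)c1ccc(S(=O)(=O)Nc2ccc(NS(=O)(=O)c3ccc(F)cc3)cc2)cc1` also stands at a limit in this assay, > 100000 nM. Going by the values given here, the single measured step, a step that the two limits leave unreadable from compound 1 to compound 3, cannot be read, since every value sits at the limit of > 100000 nM in this assay, at which 3 of the 3 values shown sit. Compound 4 `O=S(=O)(Nc1ccc(NS(=O)(=O)c2ccc(F)cc2)cc1)c1ccc(F)cc1` differs from compound 3 by fluoro in place of methylcarbamoyl on an aromatic carbon. No readable step bears on this change, and the three measured values give no direction. Compound 4 is therefore expected to give about 200000 nM in this assay, within 50000 nM to 1000000 nM, most probably again as a limit. This estimate means an expected step that the limit leaves unreadable from compound 3 to compound 4, within the scatter.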

Compound 4, inhibition constant: > 100000 nM
Compound 4: a limit, no number (the forecaster's own chance of this, stated with the estimate: 85%); the middle value lies beyond the limit too.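

In this assay compound 4 gives only a limit, > 100000 nM. The steps from compound 3 and from compound 1 to compound 4 cannot be read: the limit of > 100000 nM in this assay, at which 4 of the 4 values shown sit.

The compounds shown leave open whether any change to the shared core gives a measurable inhibition constant.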